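From pyridin-2-yl to allyloxy: estimating a short half-life

The source may report more compounds than this note shows. Statements on the series, on what has been measured and on what is new or still open speak of the compounds shown alone.

Among the measured compounds shown here, in an ADME assay on microsomes from liver (Mus musculus) for metabolic stability, read by HPLC, using NADPH, with a stated time of 60 min, tested at 1 uM, in the presence of a further agent that is not named here (on this read-out lower numbers stand for a shorter-lived compound and higher numbers for a longer-lived compound), compound 1 `Cc1cc(-c2ccccn2)cc(C(=O)NNS(=O)(=O)c2ccccc2)c1F` gives 0.0667 h as the only exact number so far. Compound 2 `CCOc1cc(C)cc(C(=O)NNS(=O)(=O)c2ccccc2F)c1` shows < 0.0334 h as a limit of the assay and not a number. Compound 3 `C=CCOc1cc(C)c(F)c(C(=O)NNS(=O)(=O)c2ccccc2)c1` carries allyloxy in place of pyridin-2-yl on an aromatic carbon and has not yet been measured. For the measured compounds named here, no measured step shows what such a swap does. The expected 1.5-fold lower number from compound 1 to compound 3 (0.17 log units; within the scatter) is therefore small, a slight fall in this assay that stays within the usual scatter. Compound 3 is estimated at 0.045 h with an expected range from 0.025 h to 0.09 h for this half-life.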

Compound 3, half-life: < 0.0334 h
Compound 3: only a limit was reported; the forecaster's own chance of this, stated with the estimate: 35%; at least 1.3-fold (0.12 log units) between middle value and limit.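

In this assay, among the compounds shown here, swapping pyridin-2-yl for allyloxy on this aromatic carbon gives the first step that can be read at this position: an at least 1.9-fold lower number from compound 1 to compound 3 (0.30 log units; that floor lies within the scatter). Compound 3 gives < 0.0334 h, which is a limit of the assay and not a number. As far as these compounds go, the full size of the step therefore stays unknown, because compound 3 sits at the same limit as another compound: the limit of < 0.0334 h in this assay, at which 2 of the 3 values shown sit.

From the compounds shown here alone, whether a methoxy group, an amine or a carboxylic acid at this place would give an exact half-life remains open. So does whether any other ring here would match pyridin-2-yl.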